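Adding a nitro group to compound 2

The source may hold more compounds than are shown below. What is called first, only, known or untested is meant among the compounds shown, and "the series" means these compounds.

In a functional assay on PANC-1 cells (Homo sapiens) for antiproliferative activity, read by sulforhodamine B assay, with a stated time of 48 h (a higher number here means a weaker inhibitor of growth, a lower number a stronger inhibitor of growth), compound 1 (`ClC1=C(c2nnc(Nc3ccccc3)s2)CCCc2ccccc21`) gives 158 nM, and compound 2 (`ClC1=C(c2nnc(-c3ccccc3)o2)CCCc2ccccc21`) gives 675 nM. Compound 2 therefore holds the higher of the two numbers, with a gap beyond the usual scatter. Compound 3 (`O=[N+]([O-])c1ccc(-c2nnc(C3=C(Cl)c4ccccc4CCC3)o2)cc1`) differs from compound 2 by a single change: nitro in place of hydrogen on an aromatic carbon. Among the measured compounds shown here, no measured pair shows this change, so only a small step is expected in this assay, towards a lower number and within the scatter: a 1.7-fold lower number from compound 2 to compound 3 (0.23 log units; within the scatter). For compound 3 the estimated value is 400 nM, with an expected range from 120 nM to 1300 nM.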

Compound 3, concentration for 50% growth inhibition: 3980 nM
Compound 3: the middle estimate sits 10-fold (1.00 log units) below what was measured; measured number above the stated range.
By their numbers in this assay, from the lowest: compound 1; then compound 2; then compound 3.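

Nitro in place of hydrogen on an aromatic carbon, para to a large group, gives a 5.9-fold higher number from compound 2 to compound 3 (0.77 log units; beyond the scatter) in this assay and makes compound 3 a weaker inhibitor of growth than compound 2. Among the compounds shown here, this is the first reading of a substituent at this place, since compounds 1 and 2 carry only hydrogen there, and it shows that the place does not tolerate every group. No measurement shown here accounts for the step.

From the compounds shown here alone, whether the weakening belongs to nitro itself or to any group at this place stays open. An amine or a methoxy group at the same place would help to separate the two.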